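One group exchanged on compound 2

The compounds below may be only part of what the source reports. "The series", "measured", "known", "first", "only" and "open" are said of these compounds alone.

Of the compounds shown here, two have been tested so far in a functional assay on HCT-116 cells (Homo sapiens) for cytotoxicity, read by MTT assay, with a stated time of 72 h; a lower number here means a stronger inhibitor, a higher number a weaker inhibitor. Compound 1 `Cc1ccc(S(=O)(=O)c2nc3ccccc3nc2Nc2cccc(N)c2)cc1` gives 2390 nM, and compound 2 `COc1ccc(Nc2nc3ccccc3nc2S(=O)(=O)c2ccc(Br)cc2)cc1` gives 3400 nM. Those two numbers lie within the usual scatter of repeated measurements, so compound 2 cannot be separated from compound 1 in this assay.

The next compound, compound 3 `Nc1cccc(Nc2nc3ccccc3nc2S(=O)(=O)c2ccc(Br)cc2)c1`, has 3-aminophenyl in place of 4-methoxyphenyl on a nitrogen on an aromatic ring. Among the measured compounds shown here, no measured step between closely matched compounds is available as a guide, so the forecast rests on these two values alone. Since they sit so close together, no shift beyond the scatter is expected, and no direction can be favoured with confidence. The estimated change, a 1.3-fold lower number from compound 2 to compound 3 (0.10 log units; within the scatter), would stay within that scatter. For compound 3 the expected value is 2700 nM, with an estimated range of 1000 nM to 7000 nM.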

Compound 3, half-maximal inhibitory concentration: 3280 nM
For compound 3 the middle estimate is 1.2-fold (0.08 log units) below the measured one; low and high end bracket the measured number.
By their numbers in this assay, from the lowest: compounds 1, 3 and 2 (each within the scatter of the next).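

In this assay, 3-aminophenyl in place of 4-methoxyphenyl on the nitrogen gives a 1.0-fold lower number from compound 2 to compound 3 (0.02 log units; within the scatter), so these two groups cannot be told apart here, even though only 3-aminophenyl carries a hydrogen-bond donor. Among the compounds shown here, the first matched comparison at the other end of the molecule, bromo in place of methyl on an aromatic carbon, gives a 1.4-fold higher number from compound 1 to compound 3 (0.14 log units; within the scatter), and these two compounds cannot be told apart either. No measurement is available that bears on this result.

On these data alone, whether this nitrogen accepts a very different group, such as a carboxylic acid or a longer carbon chain in place of the aromatic ring, remains open. As far as these compounds go, it is equally open whether a nitrile in place of bromo would separate from these compounds.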